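Solubility notes: chloro for methylsulfanyl in urea series

The source may report more compounds than this note shows. Statements on the series, on what has been measured and on what is new or still open speak of the compounds shown alone.

Measured so far:
compound 1, `Cc1cc(NC(=O)Nc2cccc(Cl)c2)c2ccccc2n1`, 800 nM
compound 2, `Cc1cc(NC(=O)Nc2ccc(F)cc2)c2ccccc2n1`, 3700 nM
compound 3, `CSc1ccc(NC(=O)Nc2cc(C)nc3ccccc23)cc1`, 1300 nM

In a physicochemical assay for solubility, at pH 7.4 (a lower number here means a less soluble compound, a higher number a more soluble compound), compound 3 sits second highest of the three numbers; its gap to compound 1 lies within the scatter, while compound 2 stands clearly above it. The next compound, compound 4 `Cc1cc(NC(=O)Nc2ccc(Cl)cc2)c2ccccc2n1`, differs from compound 3 in one place: chloro in place of methylsulfanyl on an aromatic carbon.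

Going by the values given here, two measured steps bear on this, neither directly. The step of a 2.8-fold lower number from compound 2 to compound 3 (0.45 log units; beyond the scatter) shows that putting methylsulfanyl in for fluoro on the aromatic carbon lowered the number modestly; the step of a 4.6-fold higher number from compound 1 to compound 2 (0.67 log units; beyond the scatter) shows that a fluoro placed as in compound 2, in place of chloro placed as in compound 1, raised it modestly. Among the compounds with values here, no step swaps chloro for methylsulfanyl at the same aromatic carbon. Compound 1 carries chloro and gives 800 nM, near compound 3.

For compound 4 a step of a 1.4-fold lower number from compound 3 to compound 4 (0.16 log units; within the scatter) in this assay is expected, likely within the scatter, leaning slightly lower. Compound 4 is estimated at 900 nM, range 350 nM to 2500 nM.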

Compound 4, solubility: 1400 nM
Compound 4: middle estimate off by 1.6-fold (0.19 log units), on the low side, and the stated range covers the measured number.
By their numbers in this assay, from the lowest: compounds 1, 3 and 4 (each within the scatter of the next); then compound 2.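

In this assay the direct swap of chloro for methylsulfanyl on the aromatic carbon, para to a large group, gives a 1.1-fold higher number from compound 3 to compound 4 (0.03 log units; within the scatter) and so does not separate these two groups at this position. Fluoro at the same carbon does stand apart from chloro, with a 2.6-fold lower number from compound 2 to compound 4 (0.42 log units; beyond the scatter) as the step, whereas the 4-chlorophenyl and 3-chlorophenyl isomers are not resolved, with a 1.8-fold higher number from compound 1 to compound 4 (0.24 log units; within the scatter) as their step. The data shown offer no measurement that accounts for any of these steps.

Open, on these data alone, is whether a group of another kind on this carbon, such as an amine or a carboxylic acid, would move the number beyond the scatter. Also open, as far as these compounds go, is whether a longer chain on the sulfur of methylsulfanyl would stay level with chloro.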